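The source may report more compounds than this note shows. Statements on the series, on what has been measured and on what is new or still open speak of the compounds shown alone.

In an ADME assay on HEK293 cells (Homo sapiens) for cytotoxicity, read by luminescence, with a stated time of 72 h (on this read-out higher numbers stand for an effect only at larger amounts of compound and lower numbers for an effect already at smaller amounts), compound 1 `CCOC(=O)c1c(-c2cccc(-c3ccccc3)c2)[nH]c2cc(OC)c(F)cc2c1=O` gives > 22000 nM as a limit of the assay, not a number. Compound 2 `CCOC(=O)c1c(-c2cccc(OC(F)(F)F)c2)[nH]c2cc(OC)c(F)cc2c1=O` gives > 22000 nM as a limit too. Compound 3 `CCOC(=O)c1c(-c2cccc(-c3ccccc3Cl)c2)[nH]c2cc(OC)c(F)cc2c1=O` also gives only a limit at > 22000 nM and so shares the limit of > 22000 nM in this assay, at which 3 of the 3 values shown sit, with the other two. Compound 4 `CCOC(=O)c1c(-c2cccc(-c3nc(C)c(C)s3)c2)[nH]c2cc(OC)c(F)cc2c1=O` carries 4,5-dimethyl-1,3-thiazol-2-yl in place of 2-chlorophenyl on an aromatic carbon and awaits measurement. The closest evidence is a step that the two limits leave unreadable from compound 2 to compound 3 at that same place, alongside a step that the two limits leave unreadable from compound 1 to compound 2 and a step that the two limits leave unreadable from compound 1 to compound 3 with no size to carry over. No large step is expected in this assay because compound 3 sits at > 22000 nM as a limit. The estimated a number no higher from compound 3 to compound 4 (the limit leaves the size open) therefore has no firm direction. The estimate for compound 4 is 22000 nM within a range of 9000 nM to 40000 nM and the result may well be a limit again.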

Compound 4, half-maximal effective concentration: > 22000 nM
Compound 4: only a limit was reported; the forecaster's own chance of this, stated with the estimate: 85%; the middle value lies on the limit itself.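

Compound 4 gives > 22000 nM as a limit of the assay, not a number, so its steps from compound 1, compound 2 and compound 3 cannot be read. The compounds shown leave open at what concentration any of them would harm these cells.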